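The source may hold more compounds than are shown below. What is called first, only, known or untested is meant among the compounds shown, and "the series" means these compounds.

Three carbamates that share a core carrying a selenocyanate group have been measured in a functional assay on MCF7 cells (Homo sapiens) for cytotoxicity, read by MTT assay, with a stated time of 72 h; a lower number here means a stronger inhibitor of growth, a higher number a weaker inhibitor of growth. Compound 1 `C=CCOC(=O)Nc1ccc([Se]C#N)cc1` gives 43100 nM. Compound 2 `N#C[Se]c1ccc(NC(=O)Oc2ccccc2)cc1` gives 35900 nM. Compound 3 `CCCCCCOC(=O)Nc1ccc([Se]C#N)cc1` gives 30500 nM, the lowest of the three numbers, though every gap between them lies within the scatter: a 1.4-fold lower number from compound 1 to compound 3 (0.15 log units; within the scatter), a 1.2-fold lower number from compound 2 to compound 3 (0.07 log units; within the scatter), and a 1.2-fold lower number from compound 1 to compound 2 (0.08 log units; within the scatter).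

Compound 4 `CCCCOC(=O)Nc1ccc([Se]C#N)cc1` differs from compound 3 in one place: hydrogen in place of ethyl on a saturated chain carbon, four bonds along the chain from an oxygen next to a carbonyl group. The measured step that bears most directly on this change is the one that alters the same chain, pentyl in place of vinyl on a saturated chain carbon bound to an oxygen next to a carbonyl group, and it stays within the scatter: a 1.4-fold lower number from compound 1 to compound 3 (0.15 log units; within the scatter). The exchange of hexyl for phenyl on that oxygen is equally flat: a 1.2-fold lower number from compound 2 to compound 3 (0.07 log units; within the scatter). Nothing among these compounds suggests that the length of the chain moves the number. Compound 4 is therefore expected to show no step beyond the scatter, a 1.1-fold higher number from compound 3 to compound 4 (0.03 log units; within the scatter). Compound 4 is estimated at 33000 nM, within a range from 17000 nM to 65000 nM.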

Compound 4, concentration for total growth inhibition: 20200 nM
Compound 4: the middle estimate sits 1.6-fold (0.21 log units) above what was measured, within the range that was stated.
By their numbers in this assay, from the lowest: compounds 4, 3, 2 and 1 (each within the scatter of the next, the first and the last beyond it).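

In this assay, hydrogen in place of ethyl on this chain carbon leaves compound 4 within the scatter of the hexyl carbamate (a 1.5-fold lower number from compound 3 to compound 4 (0.18 log units; within the scatter)), and butyl in place of phenyl on the oxygen also stays within it (a 1.8-fold lower number from compound 2 to compound 4 (0.25 log units; within the scatter)). The step from the allyl carbamate is the first among these compounds to pass the scatter, though only modestly (a 2.1-fold lower number from compound 1 to compound 4 (0.33 log units; beyond the scatter)), and since compound 3, which carries the hexyl chain, does not pass it from compound 1, this single step sets up no trend with chain length. Nothing given here accounts for these numbers.

The compounds shown leave open what a chain shorter than butyl, such as ethyl or methyl, or one longer than hexyl would give. They also leave open what a branched chain, or an amine or a carboxylic acid at the chain end, would give.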